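The source may hold more compounds than are shown below. What is called first, only, known or untested is meant among the compounds shown, and "the series" means these compounds.

Measured in an ADME assay on RAW264.7 cells (Mus musculus) for cytotoxicity, read by trypan blue exclusion, with a stated time of 48 h; on this read-out higher numbers stand for weaker inhibition of growth and lower numbers for stronger inhibition of growth:
compound 1 `Cc1cc(CNC2CCCCC2)c(C)n1-c1ccc(Cl)cc1` gives 10 ug/mL
compound 2 `Cc1cc(CNCc2ccc(Cl)cc2)c(C)n1-c1ccc(Cl)cc1` gives 0.1 ug/mL

Compound 2 holds the lower of the two numbers, at 0.1 ug/mL. Compound 3 `Cc1cc(CNOCc2ccccc2)c(C)n1-c1ccc(Cl)cc1` has benzyloxy in place of 4-chlorobenzyl on an amine nitrogen. For the measured compounds named here, the only measured step bearing on this is a 100-fold lower number from compound 1 to compound 2 (2.00 log units; beyond the scatter). It is large, beyond the scatter, and sits on the same amine nitrogen. A smaller step towards a higher number is expected in this assay, since both groups carry one six-membered aromatic ring of carbon only. The expected step is a 6.0-fold higher number from compound 2 to compound 3 (0.78 log units; beyond the scatter). Compound 3 is estimated at 0.6 ug/mL, with an expected range of 0.1 ug/mL to 4 ug/mL.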

Compound 3, concentration for 50% growth inhibition: 133 ug/mL
Compound 3: the middle estimate sits 220-fold (2.35 log units) below what was measured; measured number outside the range, above it.
By their numbers in this assay, from the lowest: compound 2; then compound 1; then compound 3.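

On the amine nitrogen, keeping one six-membered aromatic ring of carbon only does not preserve the read-out in this assay: benzyloxy in place of 4-chlorobenzyl gives a 1300-fold higher number from compound 2 to compound 3 (3.12 log units; beyond the scatter) and is a far larger step than any seen before. Benzyloxy also falls on the far side of cyclohexyl, with a 13-fold higher number from compound 1 to compound 3 (1.12 log units; beyond the scatter), so the position spans a much wider range than the first pair showed. No measurement here accounts for this change.

The compounds shown leave open whether the step follows the oxygen or the lost chlorine. Plain benzyl or 4-chlorobenzyloxy on the same nitrogen would separate the two.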